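The source may hold more compounds than are shown below. What is called first, only, known or untested is meant among the compounds shown, and "the series" means these compounds.

Measured compounds:
compound 1, `COc1cc(-c2cc(CO[C@@H]3O[C@H](CSc4ncn[nH]4)[C@H]4OC5(CCCC5)O[C@@H]34)on2)cc(OC)c1OC`, 59000 nM 
compound 2, `O=[N+]([O-])c1ccc(-c2nc(CO[C@@H]3O[C@H](CO)[C@H]4OC5(CCCC5)O[C@@H]34)no2)cc1`, 32000 nM 
compound 3, `CC1(C)O[C@H]2[C@H](OCc3noc(-c4ccc([N+](=O)[O-])cc4)n3)O[C@H](CSc3ncn[nH]3)[C@H]2O1`, 90000 nM 

All three were tested in a functional assay on A549 cells (Homo sapiens) for antiproliferative activity, read by sulforhodamine B assay, with a stated time of 48 h; a lower number here means a stronger inhibitor of growth, a higher number a weaker inhibitor of growth. Compound 2 gives the lowest number of the three. Compound 1 sits close to it, and the gap between compound 1 and compound 2 lies within the scatter, so no order can be read between those two. Compound 3 stands further off, and its gap from compound 2 is beyond the scatter.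

Compound 4, `O=[N+]([O-])c1ccc(-c2nc(CO[C@@H]3O[C@H](CSc4ncn[nH]4)[C@H]4OC5(CCCC5)O[C@@H]34)no2)cc1`, has not yet been measured. It differs from compound 2 in one place: (1H-1,2,4-triazol-5-yl)sulfanyl in place of hydroxy on a saturated chain carbon bound to a saturated ring carbon. Among the measured compounds shown here, no pair among the measured compounds shows this single change on its own, so its effect in this assay can only be guessed. Both compound 1 and compound 3 carry the entering group, but each differs from compound 2 in other places as well. Compound 1 gives 59000 nM. Compound 3 gives 90000 nM. The expected step from compound 2 to compound 4 is therefore small, a 1.4-fold higher number from compound 2 to compound 4 (0.15 log units; within the scatter), and not clearly beyond the scatter. Compound 4 is expected to give 45000 nM, with a range from 20000 nM to 100000 nM.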

Compound 4, concentration for 50% growth inhibition: 10000 nM
Beside the measured number, compound 4's estimate is 4.5-fold (0.65 log units) above it; measured number outside the range, below it.
By their numbers in this assay, from the lowest: compound 4; then compounds 2, 1 and 3 (each within the scatter of the next, the first and the last beyond it).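

In this assay, among the compounds shown here, compound 2 and compound 4 form the first pair that isolates this position, giving a 3.2-fold lower number from compound 2 to compound 4 (0.51 log units; beyond the scatter). This shows that, on this core, (1H-1,2,4-triazol-5-yl)sulfanyl in place of hydroxy on a saturated chain carbon bound to a saturated ring carbon goes with stronger growth inhibition, by a modest step beyond the scatter, a direction that compound 1 and compound 3 could not show, as each differs from compound 2 in other places as well. No measurement at hand accounts for this step.

The compounds shown leave open whether the step follows the sulfur link or the five-membered aromatic ring, which a methylsulfanyl group, an amine or a carboxylic acid at the same carbon could help separate. They also leave open whether the same change holds on the cores of compound 1 and compound 3, neither of which has a hydroxy partner here.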